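This account rests on a few compounds, and the source may have more. Where it says the series, first, only, none or still open, it means among the compounds named here.

Measured compounds:
compound 1 `CCCS(=O)(=O)Nc1cccc2c1CCC2c1ncc[nH]1` — 1340 nM
compound 2 `c1ccc2c(c1)CCC2c1ncc[nH]1` — 473 nM
compound 3 `c1cncc(-c2cccc3c2CCC3c2ncc[nH]2)c1` — 2060 nM

In a functional assay on CHO cells for agonist activity at Alpha-1A adrenergic receptor (Homo sapiens), read by FLIPR and calcium flux (on this read-out lower numbers stand for an effect already at smaller amounts and higher numbers for an effect only at larger amounts of compound), compound 1 holds the second highest of the three numbers. The nearest is a 1.5-fold higher number from compound 1 to compound 3 (0.19 log units; within the scatter); the furthest is a 2.8-fold lower number from compound 1 to compound 2 (0.45 log units; beyond the scatter).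

Compound 4 `c1cc(-c2ncco2)c2c(c1)C(c1ncc[nH]1)CC2` differs from compound 1 in 1,3-oxazol-2-yl in place of (propylsulfonyl)amino on an aromatic carbon. For the measured compounds named here, two steps bear on it. One is a 1.5-fold higher number from compound 1 to compound 3 (0.19 log units; within the scatter), an aromatic ring in place of the same group at the same carbon, which stayed within the scatter. The other is a 2.8-fold lower number from compound 1 to compound 2 (0.45 log units; beyond the scatter), which removed the group and gave a modest step. A five-membered aromatic ring entering here is therefore expected to give no step beyond the scatter, a 1.1-fold higher number from compound 1 to compound 4 (0.05 log units; within the scatter). Compound 4 is estimated at 1500 nM, within 600 nM to 4000 nM.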

Compound 4, half-maximal effective concentration: 170 nM
For compound 4 the middle estimate is 8.8-fold (0.95 log units) above the measured one; the whole stated range lies above it.
By their numbers in this assay, from the lowest: compound 4; then compound 2; then compounds 1 and 3 (each within the scatter of the next).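

In this assay, this aromatic carbon can carry a substituent and still give a lower number than the unsubstituted compound (a 2.8-fold lower number from compound 2 to compound 4 (0.44 log units; beyond the scatter)), which neither (propylsulfonyl)amino nor pyridin-3-yl did. The identity of the aromatic ring matters here, since 1,3-oxazol-2-yl and pyridin-3-yl separate clearly (a 12-fold lower number from compound 3 to compound 4 (1.08 log units; beyond the scatter)), and 1,3-oxazol-2-yl also stands apart from (propylsulfonyl)amino (a 7.9-fold lower number from compound 1 to compound 4 (0.90 log units; beyond the scatter)). No available evidence accounts for these differences.

Going by these compounds, it remains open whether the low number is specific to 1,3-oxazol-2-yl or extends to other five-membered aromatic rings. An amine or a carboxylic acid on this carbon also remains untested among the compounds shown.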